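The compounds below may be only part of what the source reports. "The series", "measured", "known", "first", "only" and "open" are said of these compounds alone.

Measured compounds in a functional assay on HT-29 cells (Homo sapiens) for antiproliferative activity, read by sulforhodamine B assay, with a stated time of 48 h; a higher number here means a weaker inhibitor, a lower number a stronger inhibitor:
compound 1 `CCC(=O)Nc1cccc(S(=O)(=O)Oc2ccccc2C(C)C)c1` gives 22000 nM;
compound 2 `CCCC(=O)Nc1cccc(S(=O)(=O)Oc2ccccc2C(C)C)c1` gives 13000 nM;
compound 3 `CCCCCC(=O)Nc1cccc(S(=O)(=O)Oc2ccccc2C(C)C)c1` gives 19000 nM.

Compound 3 stands second highest of the three numbers. Its nearest neighbour is compound 1, with a 1.2-fold lower number from compound 1 to compound 3 (0.06 log units; within the scatter); the furthest is compound 2, with a 1.5-fold higher number from compound 2 to compound 3 (0.16 log units; within the scatter). Compound 4 `CC(C)C(=O)Nc1cccc(S(=O)(=O)Oc2ccccc2C(C)C)c1` differs from compound 3 by isopropyl in place of pentyl on a carbonyl carbon. Among the compounds with values here, the steps that bear on this change all alter the same acyl chain: a 1.7-fold lower number from compound 1 to compound 2 (0.23 log units; within the scatter), a 1.2-fold lower number from compound 1 to compound 3 (0.06 log units; within the scatter) and a 1.5-fold higher number from compound 2 to compound 3 (0.16 log units; within the scatter), each within the scatter. No step beyond the scatter is therefore expected, a 1.1-fold lower number from compound 3 to compound 4 (0.05 log units; within the scatter). Compound 4 is estimated at 17000 nM, in a range from 8000 nM to 36000 nM.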

Compound 4, half-maximal inhibitory concentration: 16000 nM
Compound 4: middle estimate off by 1.1-fold (0.03 log units), on the high side, and the stated range covers the measured number.
By their numbers in this assay, from the lowest: compounds 2, 4, 3 and 1 (each within the scatter of the next).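

In this assay, a branched isopropyl on the carbonyl carbon stays within the scatter of each straight chain: pentyl (a 1.2-fold lower number from compound 3 to compound 4 (0.07 log units; within the scatter)), propyl (a 1.2-fold higher number from compound 2 to compound 4 (0.09 log units; within the scatter)) and ethyl (a 1.4-fold lower number from compound 1 to compound 4 (0.14 log units; within the scatter)). Branching thus joins chain length as a change that gives no step beyond the scatter among these four compounds. No evidence is available that bears on this result. Still open, going by these compounds, is whether a phenyl ring, an amine or a carboxylic acid on this carbonyl carbon would give a step beyond the scatter.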